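The compounds below may be only part of what the source reports. "The series", "measured", "known", "first", "only" and "open" are said of these compounds alone.

Compound 1, `COc1cc2c(Oc3ccc(NC(=O)c4nn(-c5ccccc5)c(=O)cc4C)cc3F)ccnc2cc1OCCCN1CCCC1`, is the starting point of this small set; in a functional assay on HT-29 cells (Homo sapiens) for inhibition, read by MTT assay, with a stated time of 72 h (a higher number here means a weaker inhibitor, a lower number a stronger inhibitor), compound 1 gives 220 nM. Compound 2, `COc1cc2c(Oc3ccc(NC(=O)c4nn(-c5ccccc5)c(=O)cc4C)cc3F)ccnc2cc1OCCCN1CCN(C)CC1`, carries 4-methylpiperazin-1-yl in place of pyrrolidin-1-yl on a saturated chain carbon, three bonds along the chain from an oxygen on an aromatic ring and in this assay compound 2 gives 270 nM; the change made a 1.2-fold higher number from compound 1 to compound 2 (0.09 log units; within the scatter). Compound 3, `COc1cc2c(Oc3ccc(NC(=O)c4nn(-c5ccc(F)c(F)c5)c(=O)cc4C)cc3F)ccnc2cc1OCCCN1CCCC1`, differs from compound 1 by 3,4-difluorophenyl in place of phenyl on an aromatic nitrogen; in this assay compound 3 gives 150 nM, and the step is a 1.5-fold lower number from compound 1 to compound 3 (0.17 log units; within the scatter). All three numbers therefore sit close together, and none of the compounds can be singled out as stronger or weaker than another.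

Compound 4, `COc1cc2c(Oc3ccc(NC(=O)c4nn(-c5ccc(F)c(F)c5)c(=O)cc4C)cc3F)ccnc2cc1OCCCN1CCN(C)CC1`, has not yet been measured. It differs from compound 3 by 4-methylpiperazin-1-yl in place of pyrrolidin-1-yl on a saturated chain carbon, three bonds along the chain from an oxygen on an aromatic ring. This is the same change as that from compound 1 to compound 2, made here on the core of compound 3, which differs from the core of compound 1 by 3,4-difluorophenyl in place of phenyl on an aromatic nitrogen. The place of the change is the same in both pairs. The step from compound 3 to compound 4 is expected to be a 1.2-fold higher number from compound 3 to compound 4 (0.08 log units; within the scatter), because a 1.2-fold higher number from compound 1 to compound 2 (0.09 log units; within the scatter) stayed within the scatter. Compound 4 is therefore estimated to give 180 nM, with a range from 90 nM to 360 nM.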

Compound 4, half-maximal inhibitory concentration: 170 nM
For compound 4 the middle estimate is 1.1-fold (0.02 log units) above the measured one; low and high end bracket the measured number.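

In this assay, 4-methylpiperazin-1-yl in place of pyrrolidin-1-yl gives a 1.1-fold higher number from compound 3 to compound 4 (0.05 log units; within the scatter), and 3,4-difluorophenyl in place of phenyl on an aromatic nitrogen gives a 1.6-fold lower number from compound 2 to compound 4 (0.20 log units; within the scatter). The first change reads alike on both cores: the same change on two cores in this assay, a 1.2-fold higher number (0.09 log units; within the scatter) from compound 1 to compound 2 and a 1.1-fold higher number (0.05 log units; within the scatter) from compound 3 to compound 4, 1.1-fold (0.03 log units) apart, within the scatter of two such steps. The second reads alike too, but every one of these steps lies within the scatter, so this shows only that neither change has a readable effect on these two cores, not that a change with a clear effect would carry over in the same way: the same change on two cores in this assay, a 1.5-fold lower number (0.17 log units; within the scatter) from compound 1 to compound 3 and a 1.6-fold lower number (0.20 log units; within the scatter) from compound 2 to compound 4, 1.1-fold (0.03 log units) apart, within the scatter of two such steps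

The compounds shown leave open what other groups would do at these two places, such as morpholin-4-yl or dimethylamino at the end of the chain, a longer chain, or a chlorophenyl on the aromatic nitrogen. They also leave open whether the same picture holds outside this assay.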